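From chloro to difluorophenyl: a solubility step near the limit

The compounds below may be only part of what the source reports. "The series", "measured", "known", "first", "only" and "open" are said of these compounds alone.

In a physicochemical assay for solubility (on this read-out higher numbers stand for higher solubility and lower numbers for lower solubility), compound 1 `O=C(Nc1ccccc1Cl)c1cc(Cl)ccc1O` gives 5 ug/mL. Compound 2 `N#Cc1ccc(NC(=O)c2cc(Cl)ccc2O)c(Cl)c1` gives < 1 ug/mL, which is a limit and not a number. As far as these compounds go, compound 3 `O=C(Nc1ccc(C(F)(F)F)cc1Cl)c1cc(Cl)ccc1O` gives < 1 ug/mL, again only a limit, so its true standing is unknown. Compound 4 `O=C(Nc1ccc(C(F)(F)F)cc1Cl)c1cc(-c2ccc(F)cc2F)ccc1O` carries 2,4-difluorophenyl in place of chloro, para to a hydroxy group: 2,4-difluorophenyl in place of chloro on an aromatic carbon. Among the compounds with values here, no measured step touches this place, so the nearest guides are changes made elsewhere: an at least 5.0-fold lower number from compound 1 to compound 2 (0.69 log units; beyond the scatter) and an at least 5.0-fold lower number from compound 1 to compound 3 (0.69 log units; beyond the scatter). Both lie beyond the scatter, and both added a group and went down. On those two steps, a further fall is expected, giving an estimated step that the limit leaves unreadable from compound 3 to compound 4. For compound 4 the estimate is 0.5 ug/mL, with an expected range from 0.1 ug/mL to 1.5 ug/mL.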

Compound 4, solubility: < 1 ug/mL
Compound 4: no number, only a limit (the forecaster's own chance of this, stated with the estimate: 85%); the middle value does not contradict the limit.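

Compound 3 and compound 4 each give only a limit, not a number, so no step between them can be read: the limit of < 1 ug/mL in this assay, at which 3 of the 4 values shown sit.

The compounds shown leave open whether 2,4-difluorophenyl in place of chloro changes solubility at all, and in which direction.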